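Compound 3 to compound 4: a larger amine on the core

A few compounds are considered here, and "the series" means these few. Any claim that something is new, unique, unknown or untested is made for them only; others in the source may bear on it.

Of the compounds shown here, three have been read in a functional assay on L02 cells (Homo sapiens) for inhibition, read by Griess assay, with stated times of 1 h and 24 h (on this read-out higher numbers stand for weaker inhibition and lower numbers for stronger inhibition), and none of them gives a number. Compound 1 `COc1ccc(Nc2nc(/C=C/c3ccccc3)nc3ccsc23)cc1` stands at > 1000000 nM, which is a limit of the assay. Compound 2 `C(=C/c1ccco1)\c1nc(NC2CC2)c2sccc2n1` stands at > 1000000 nM, again a limit. Compound 3 `COc1cc(/C=C/c2nc(N(C)C)c3sccc3n2)cc(OC)c1OC` stands at > 1000000 nM, also a limit. Compound 3 therefore has no number of its own, and the whole set rests on a single point: the limit of > 1000000 nM in this assay, at which 3 of the 3 values shown sit.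

The next entry is compound 4 `CCN1CCN(c2nc(/C=C/c3cc(OC)c(OC)c(OC)c3)nc3ccsc23)CC1`, which carries 4-ethylpiperazin-1-yl in place of dimethylamino on an aromatic carbon, next to the ring nitrogen (4-ethylpiperazin-1-yl in place of dimethylamino on an aromatic carbon). Among the compounds with values here, no two measured compounds differ in one place only, so the data give no direct size for such a step in this assay. The expectation rests on compound 3 at > 1000000 nM and on the fact that all three readings so far are limits. No step beyond the scatter is expected, and another limit is the likeliest report. The estimated value for compound 4 is 1000000 nM, with an expected range of 300000 nM to 1000000 nM. This estimate means a number no higher from compound 3 to compound 4 (the limit leaves the size open), which is expected to stay within the scatter.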

Compound 4, half-maximal inhibitory concentration: > 1000000 nM
Compound 4 gave a limit, no number; the forecaster's own chance of this, stated with the estimate: 75%; the middle value sits exactly at the limit.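

Compound 3 and compound 4 both end at a limit in this assay, so no step can be read between them. The compounds shown leave open whether any change on the shared core brings a measurable number, as all the readings rest on a single point: the limit of > 1000000 nM in this assay, at which 4 of the 4 values shown sit.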